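Removing one methoxy group: expected cytotoxicity of compound 3

The source may report more compounds than this note shows. Statements on the series, on what has been measured and on what is new or still open speak of the compounds shown alone.

Compound 1 `COc1ccc(-c2cc(/C=C/C(=O)c3ccc(N)cc3)[nH]n2)cc1` and compound 2 `COc1cc(-c2cc(/C=C/C(=O)c3ccc(N)cc3)[nH]n2)cc(OC)c1OC` share one core and differ only in how many methoxy groups sit on the aromatic ring that carries them. In a functional assay on HCT-116 cells (Homo sapiens) for cytotoxicity, read by sulforhodamine B assay, with a stated time of 48 h, tested at 0.01 uM (a higher number here means a weaker effect of the compound at the concentration tested, a lower number a stronger effect), compound 1 gives 97%. In this assay compound 2 gives 95%; of the two numbers shown this is the lower one, yet the two values lie within the scatter of each other, so no order can be read from them, and both compounds leave most of the cells alive at this concentration.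

Compound 3 `COc1ccc(-c2cc(/C=C/C(=O)c3ccc(N)cc3)[nH]n2)cc1OC` has not yet been measured. Its difference from compound 2 is hydrogen in place of methoxy on an aromatic carbon. Among the measured compounds shown here, no single-change step among measured compounds is available, so the expectation rests on the two values alone. Because compound 1 gives 97% and compound 2 gives 95%, values within the scatter of each other despite a difference of two methoxy groups, the expected step is a number 1 percentage points higher from compound 2 to compound 3 (within the scatter), nothing beyond the scatter in either direction. Compound 3 is therefore expected to give 96% in this assay, with a range of 88% to 102%.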

Compound 3, a percentage reported as activity, at one concentration (the size of the read-out at that concentration, not a potency): 96%
Compound 3: middle estimate and measured number agree at the digits printed; the range from low to high includes it.
By their numbers in this assay, from the lowest: compounds 2, 3 and 1 (each within the scatter of the next).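

Two single-place steps can now be read on this ring in this assay: hydrogen in place of methoxy on an aromatic carbon, ortho to a methoxy group and meta to a large group, gives a number 1 percentage points higher from compound 2 to compound 3 (within the scatter), and methoxy in place of hydrogen on an aromatic carbon gives a number 1 percentage points lower from compound 1 to compound 3 (within the scatter). Compounds 1 and 2 differ by two methoxy groups, so they could not separate the contribution of one group, whereas both of these steps isolate a single methoxy group and both stay within the scatter, so at this one concentration neither shows a detectable effect of that group on the read-out. No measured evidence bears on why this is so.

The compounds shown carry only methoxy or hydrogen on these ring carbons, so it stays open whether a hydroxyl group, a chlorine atom or a longer alkoxy chain there would move the number beyond the scatter. Going by these compounds, with one low concentration as the only read-out, it also stays open whether compounds 1, 2 and 3 would separate at higher concentrations, where a full concentration-response comparison could show differences hidden here.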